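A Charged Ring Enters at Compound 3

This account rests on a few compounds, and the source may have more. Where it says the series, first, only, none or still open, it means among the compounds named here.

For the measured compounds named here, in a functional assay on HepG2 cells (Homo sapiens) for cytotoxicity, read by MTT assay, with a stated time of 48 h (on this read-out higher numbers stand for weaker inhibition and lower numbers for stronger inhibition), compound 1 (`CC1=NN(C(=O)CCl)C(c2cc(Br)ccc2O)C1`) gives 16300 nM and compound 2 (`COc1ccccc1C1CC(C)=NN1C(=O)CN1CCC(OC)CC1`) gives 22000 nM, so compound 2 stands within the scatter of the only other measured value. Compound 3 (`COc1ccccc1C1CC(C)=NN1C(=O)C[N+]1(C)CCCC1`) awaits measurement and differs from compound 2 as follows: a group of 6 heavy atoms (5 carbon, 1 nitrogen; one five-membered non-aromatic ring with 1 hetero atom) in place of a group of 8 heavy atoms (6 carbon, 1 nitrogen, 1 oxygen; one six-membered non-aromatic ring with 1 hetero atom), on a saturated chain carbon bound to a carbonyl carbon. Going by the values given here, no measured pair shows the effect of such a change, so no shift beyond the scatter is expected in this assay, in either direction. The expected step is a 1.1-fold higher number from compound 2 to compound 3 (0.04 log units; within the scatter). For compound 3, the estimated value is 24000 nM, with an expected range of 8000 nM to 70000 nM.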

Compound 3, half-maximal inhibitory concentration: 32200 nM
Compound 3: middle estimate off by 1.3-fold (0.13 log units), on the low side; low and high end bracket the measured number.
By their numbers in this assay, from the lowest: compounds 1, 2 and 3 (each within the scatter of the next).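

In this assay, replacing the 4-methoxypiperidin-1-yl group with a five-membered ring of net charge +1 gives a 1.5-fold higher number from compound 2 to compound 3 (0.17 log units; within the scatter). This first measured pair at a saturated chain carbon bound to a carbonyl carbon shows that a group with net charge +1 and no hydrogen-bond acceptors can stand there without a shift beyond the scatter. No accompanying measurement speaks to the reason for this result.

For the compounds shown here, the single step does not separate the charge from the ring size. From the compounds shown here alone, whether a primary amine or a carboxylic acid at this place would move the number beyond the scatter remains open.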